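Isopropyl in place of 2-methoxyethyl: working notes

This account rests on a few compounds, and the source may have more. Where it says the series, first, only, none or still open, it means among the compounds named here.

Values so far in an ADME assay on liver (Mus musculus, strain CD-1) for metabolic stability, read by LC-MS, using microsomes and NADPH, with a stated time of 5 min, tested at 1 uM (a higher number here means that the compound lasts longer, a lower number that the compound disappears faster), are these:
compound 1 `COc1ncc(NC(=O)C(=O)c2cn(C(C)C)c3ccccc23)cn1` gives 0.0833 h
compound 2 `COc1ccc(NC(=O)C(=O)c2cn(C(C)C)c3ccccc23)cn1` gives 0.0833 h
compound 3 `COCCc1cc(C(=O)C(=O)Nc2ccc(OC)nc2)c2ccccn12` gives 0.1 h

Compound 3 at 0.1 h lies within the usual scatter of both compound 1 and compound 2, so the three numbers do not separate. Compound 4 `COc1ccc(NC(=O)C(=O)c2cc(C(C)C)n3ccccc23)cn1` is still unmeasured. Its difference from compound 3 is isopropyl in place of 2-methoxyethyl on an aromatic carbon with isopropyl in place of 2-methoxyethyl on an aromatic carbon of a five-membered aromatic ring with 1 nitrogen, part of a fused or bridged system of two rings.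

Within the data shown here, the one measured step is no change at the digits printed from compound 1 to compound 2 (within the scatter) and it concerns a group on an amide-type nitrogen, so it bears on this exchange only indirectly. Among the measured compounds shown here, no measured pair covers the exchange itself. Compound 2 also carries isopropyl, on a different core, and gives 0.0833 h within the scatter of compound 3. On this thin evidence, no step beyond the scatter is expected in this assay in either direction. The estimated step is a 1.1-fold lower number from compound 3 to compound 4 (0.05 log units; within the scatter) and it is expected to stay within the scatter. For compound 4 the estimate is 0.09 h with 0.06 h to 0.16 h as the expected range.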

Compound 4, half-life: < 0.0834 h
Compound 4: a limit, no number; the forecaster's own chance of this, stated with the estimate: 15%; middle value at least 1.0-fold (0.03 log units) from the limit.
By their numbers in this assay, from the lowest: compounds 1, 2 and 3 (each within the scatter of the next).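

In this assay compound 4 carries a limit and not a number: the limit of < 0.0834 h in this assay, at which 1 of the 4 values shown sits.

Among these compounds, this is the first measured pair for the exchange of 2-methoxyethyl for isopropyl on an aromatic carbon of a five-membered aromatic ring with 1 nitrogen, part of a fused or bridged system of two rings, and it reads as an at least 1.1-fold lower number from compound 3 to compound 4 (0.07 log units; that floor lies within the scatter). Only a floor is available for this step, so it remains unsettled whether the true size stays within the scatter or goes beyond it. What the pair adds is that isopropyl at this place, next to the ring nitrogen, does not bring the half-life clear of the limit, whereas the 2-methoxyethyl compound has a measured number.

As far as these compounds go, how far compound 4 actually lies under the limit stays open, and with it the true size of this step. Also open, from the compounds shown here alone, is whether an amine, a carboxylic acid or a longer chain with an ether oxygen on this same aromatic carbon would give a half-life that separates from compound 3 beyond the scatter.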